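Removing the ethyl from the ether of compound 3

The compounds below may be only part of what the source reports. "The series", "measured", "known", "first", "only" and "open" are said of these compounds alone.

Measured so far:
- compound 1 `COc1cc2nc(N3CCC(OCCO)CC3)nc(N)c2cc1OC`: 2.2 nM
- compound 2 `CCOCC(OC1CCN(c2nc(N)c3cc(OC)c(OC)cc3n2)CC1)c1ccccc1`: 10 nM
- compound 3 `CCOC(COC1CCN(c2nc(N)c3cc(OC)c(OC)cc3n2)CC1)c1ccccc1`: 0.52 nM

All three compounds share a core and differ only in the chain on the oxygen of the saturated ring. In an assay on brain for displacement of a labelled ligand from Adrenergic receptor alpha-1 (Rattus norvegicus) (on this read-out lower numbers stand for stronger inhibition and higher numbers for weaker inhibition), compound 3 stands lowest of the three numbers shown, with compound 1 nearest and compound 2 furthest. The step of a 4.2-fold lower number from compound 1 to compound 3 (0.63 log units; beyond the scatter) shows that placing ethoxy(phenyl)methyl in place of hydroxymethyl on that chain gave a modest gain, while a 19-fold lower number from compound 2 to compound 3 (1.28 log units; beyond the scatter) shows a large gain from moving the ether group along the chain.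

Compound 4 `COc1cc2nc(N3CCC(OCC(O)c4ccccc4)CC3)nc(N)c2cc1OC` differs from compound 3 by hydrogen in place of ethyl on an oxygen on a saturated carbon. This leaves the phenyl in place but returns a free hydroxy, so compound 4 sits structurally between compound 1 and compound 3. Since compound 1 gives 2.2 nM and compound 3 gives 0.52 nM, the expected outcome for compound 4 is a small rise, a 2.1-fold higher number from compound 3 to compound 4 (0.33 log units; beyond the scatter). The estimate for compound 4 is 1.1 nM, with a range from 0.4 nM to 3.2 nM.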

Compound 4, inhibition constant: 0.15 nM
For compound 4 the middle estimate is 7.3-fold (0.87 log units) above the measured one; the whole stated range lies above it.
By their numbers in this assay, from the lowest: compound 4; then compound 3; then compound 1; then compound 2.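

Removing the ethyl does not cost anything here: in this assay, hydrogen in place of ethyl on this oxygen gives a 3.5-fold lower number from compound 3 to compound 4 (0.54 log units; beyond the scatter) and leaves a free hydroxy, so the ethyl is not needed for the low number of compound 3. Compound 4 also shows the phenyl without the ethyl, and phenyl in place of hydrogen on this saturated chain carbon gives a 15-fold lower number from compound 1 to compound 4 (1.17 log units; beyond the scatter) in this series. The placement of the groups on the chain matters as well, since 2-hydroxy-2-phenylethyl in place of 2-ethoxy-1-phenylethyl gives a 67-fold lower number from compound 2 to compound 4 (1.82 log units; beyond the scatter) and this is the widest step among these compounds.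

From the compounds shown here alone, whether an amine or a carboxylic acid in place of the hydroxy, or a longer chain, would hold the number this low remains open. The data shown offer no explanation for any of these steps.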